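This account rests on a few compounds, and the source may have more. Where it says the series, first, only, none or still open, it means among the compounds named here.

Measured compounds:
- compound 1 `ClCc1ccc(Cn2cnc3nc(Cl)nc(Cl)c32)cc1`: 2810 nM
- compound 2 `ClCc1cccc(Cn2cnc3c(Cl)nc(Cl)nc32)c1`: 5120 nM
- compound 3 `ClCc1ccc(Cn2cnc3c(Cl)nc(Cl)nc32)cc1`: 30200 nM

In a functional assay on IGROV-1 cells (Homo sapiens) for cytotoxicity, read by sulforhodamine B assay, with a stated time of 48 h (a higher number here means a weaker inhibitor of growth, a lower number a stronger inhibitor of growth), compound 1 gives 2810 nM, the lowest number among the three measured compounds. Compound 2 gives 5120 nM, and that figure is within the scatter of compound 1, so no order can be drawn between the two. Compound 3 gives 30200 nM, which sits beyond the scatter above compound 1.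

Compound 4 `ClCc1ccc(Cn2cnc3ncnc(Cl)c32)cc1` has not yet been measured. It differs from compound 1 in one place: hydrogen in place of chloro on an aromatic carbon. No step between measured compounds mirrors this change, so the size of the step rests only on the three numbers shown. The account expects compound 4 to give a somewhat higher number in this assay than compound 1, a step of about a 1.8-fold higher number from compound 1 to compound 4 (0.25 log units; within the scatter), though one that may not exceed the scatter. Compound 4 is therefore estimated at 5000 nM, with a range from 1500 nM to 18000 nM.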

Compound 4, concentration for total growth inhibition: 30900 nM
Compound 4: middle estimate off by 6.2-fold (0.79 log units), on the low side; the whole stated range lies below it.
By their numbers in this assay, from the lowest: compounds 1 and 2 (each within the scatter of the next); then compounds 3 and 4 (each within the scatter of the next).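

Among the compounds shown here, replacing the chloro on the aromatic carbon between two ring nitrogen atoms with hydrogen gives an 11-fold higher number from compound 1 to compound 4 (1.04 log units; beyond the scatter) in this assay and, unlike the earlier comparisons, this one isolates a single place in the core of compound 1. The step lies beyond the scatter, so the presence of this one chloro, a single heavy atom, separates compound 1 from compound 4 even though the second chloro, meta to this position, stays in both. The compounds shown offer no explanation for the size of this step.

What they leave open is whether the position needs chlorine itself or would tolerate another group, such as an amine, a methoxy group or a bromine atom. They also leave open whether removing the second chloro from compound 1 would produce a step of similar size.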